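Methoxy in Place of Methyl: Expected Hepatic Extraction

A few compounds are considered here, and "the series" means these few. Any claim that something is new, unique, unknown or untested is made for them only; others in the source may bear on it.

Compound 1, `COc1ccc(-n2cnc3cnc(-c4ccccc4)cc32)cc1OC`: 1
Compound 2, `COc1ccc(-n2cnc3cnc(-c4ccccc4C)cc32)cc1OC`: 1
Compound 3, `COc1ccc(-n2cnc3cnc(-c4cc(F)ccc4C)cc32)cc1OC`: 1

All three were tested in an ADME assay on S9 fraction from liver (Mus musculus) for metabolic stability, read by LC-MS, using NADPH, with a stated time of 45 min, tested at 3 uM, in the presence of a further agent that is not named here; on this read-out higher numbers stand for higher hepatic extraction and lower numbers for lower hepatic extraction. Compound 3 stands level with compounds 1 and 2: the steps of no change at the digits printed from compound 1 to compound 3 (within the scatter) and no change at the digits printed from compound 2 to compound 3 (within the scatter) both lie within the scatter, as does no change at the digits printed from compound 1 to compound 2 (within the scatter). Compound 4, `COc1ccc(-n2cnc3cnc(-c4cc(F)ccc4OC)cc32)cc1OC`, has not yet been measured. It differs from compound 3 by methoxy in place of methyl on an aromatic carbon. Among the compounds with values here, no measured step makes this same change; the closest comparisons are no change at the digits printed from compound 1 to compound 2 (within the scatter) and no change at the digits printed from compound 2 to compound 3 (within the scatter), neither of which moved the read-out beyond the scatter. A step no larger than the scatter is therefore expected, so for compound 4 the estimated step is no change at the digits printed from compound 3 to compound 4 (within the scatter). Compound 4 is expected to give 1 in this assay, within the range 0.9 to 1.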

Compound 4, hepatic extraction ratio in the Mus musculus assay: 1
Compound 4: the middle estimate sits on the measured number at the digits printed; measured number inside the range.
By their numbers in the Mus musculus assay, from the lowest: compounds 1, 2, 3 and 4 (each within the scatter of the next).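

In the Mus musculus assay the swap to methoxy leaves the read-out flat, no change at the digits printed from compound 3 to compound 4 (within the scatter), and the wider comparisons agree, no change at the digits printed from compound 2 to compound 4 (within the scatter) and no change at the digits printed from compound 1 to compound 4 (within the scatter). In a physicochemical assay for solubility (a lower number here means a less soluble compound, a higher number a more soluble compound), compound 3 gives 157000 nM and compound 4 gives 9000 nM. Methoxy in place of methyl at this position, ortho to a large group, therefore costs solubility while hepatic extraction stays level: the measured solubility of compound 3, 157000 nM, and of compound 4, 9000 nM, a 17-fold lower number (1.24 log units; beyond the scatter)

Going by these compounds, whether an amine or a carboxylic acid at this position would move hepatic extraction stays open. Also open, on these data alone, is whether the solubility step would recur without the fluoro group.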